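The source may hold more compounds than are shown below. What is called first, only, known or untested is meant among the compounds shown, and "the series" means these compounds.

Compound 1 `O=C1C(=O)N(CCCCn2cc(COc3cc(=O)oc4ccccc34)nn2)c2ccccc21`: 8050 nM
Compound 2 `O=C1C(=O)N(CCCn2cc(COc3cc(=O)oc4ccccc34)nn2)c2ccccc21`: 5180 nM

In a functional assay on HCT-116 cells (Homo sapiens) for inhibition, read by sulforhodamine B assay, with a stated time of 48 h (a lower number here means a stronger inhibitor, a higher number a weaker inhibitor), compound 2 gives 5180 nM, the smaller of the two numbers, yet the gap to compound 1 is within the scatter, so the two are not told apart. Compound 3 `O=C1C(=O)N(CCCn2cc(COc3cc(=O)oc4ccccc34)nn2)c2ccc(F)cc21` differs from compound 2 by fluoro in place of hydrogen on an aromatic carbon. Among the compounds with values here, no measured pair shows this change, so nothing in the data points to a step beyond the scatter in either direction. Compound 3 is therefore expected to give about 4500 nM, between 2000 nM and 10000 nM, a step of a 1.2-fold lower number from compound 2 to compound 3 (0.06 log units; within the scatter) that is estimated to stay within the scatter.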

Compound 3, half-maximal inhibitory concentration: 7260 nM
For compound 3 the middle estimate is 1.6-fold (0.21 log units) below the measured one; the range from low to high includes it.
By their numbers in this assay, from the lowest: compounds 2, 3 and 1 (each within the scatter of the next).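

In this assay, the step of fluoro in place of hydrogen on the six-membered aromatic ring of the core is a 1.4-fold higher number from compound 2 to compound 3 (0.15 log units; within the scatter), so compound 2 and compound 3 cannot be told apart. This position therefore accepts a fluorine atom with no measurable difference in this read-out. Nothing measured here bears on the reason for this result. On these data alone, it remains open whether chloro, methoxy or an amine at this place would give a step beyond the scatter, and whether fluoro would give the same result on the longer chain of compound 1.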